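Notes on lipophilicity around compound 1

The compounds below may be only part of what the source reports. "The series", "measured", "known", "first", "only" and "open" are said of these compounds alone.

Measured so far in a physicochemical assay for lipophilicity, at pH 7.4; a lower number here means a more polar compound, a higher number a more lipophilic compound:
compound 1, `CS(=O)(=O)N1C[C@H](C(=O)Nc2ccc(Cl)cc2)[C@@H](C(=O)Nc2ccc(-n3ccccc3=O)cc2F)C1`, 2.17
compound 2, `CCCOC(=O)N1C[C@H](C(=O)Nc2ccc(Cl)cc2)[C@@H](C(=O)Nc2ccc(-n3ccccc3=O)cc2F)C1`, 3.06
compound 3, `O=C(Nc1ccc(Cl)cc1)[C@H]1CN(CC2CC2)C[C@@H]1C(=O)Nc1ccc(-n2ccccc2=O)cc1F`, "not determined" (no result reported)

Compound 1 holds the lowest of the two numbers in this assay; the nearest is compound 2, and between them stands a number 0.89 log units higher from compound 1 to compound 2 (beyond the scatter), a change of the group on the amine nitrogen in the ring.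

Compound 4, `CS(=O)(=O)N1C[C@H](C(=O)Nc2ccc(Cl)c(F)c2)[C@@H](C(=O)Nc2ccc(-n3ccccc3=O)cc2F)C1`, is not yet measured. Relative to compound 1 it carries the change (fluoro in place of hydrogen on an aromatic carbon). For the measured compounds named here, no measured step involves this change; the single measured step concerns the amine nitrogen in the ring and gives no guide to a fluoro on the aromatic carbon. In this assay compound 4 is expected to show a number 0.18 log units higher from compound 1 to compound 4 (within the scatter), small and possibly within the scatter. Compound 4 is estimated at 2.35, with a range of 2.05 to 2.65.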

Compound 4, distribution coefficient: 2.37
Compound 4: middle estimate off by 0.02 log units, on the low side; low and high end bracket the measured number.
By their numbers in this assay, from the lowest: compounds 1 and 4 (each within the scatter of the next); then compound 2.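

Going from 4-chlorophenyl to 4-chloro-3-fluorophenyl gives, in this assay, a number 0.20 log units higher from compound 1 to compound 4 (within the scatter), so at this aromatic carbon, ortho to a chloro group, the fluoro leaves no step that can be told from the scatter. For the compounds shown here, this is the only reading at this end of the molecule, as the earlier step concerned the amine nitrogen in the ring. Nothing available accounts for the size of this step.

From the compounds shown here alone, whether a methoxy, a trifluoromethyl or an amine at this carbon gives a step beyond the scatter stays open. So does whether fluoro gives a similar step with the propoxycarbonyl group of compound 2 on the ring nitrogen.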